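Bromo for ethyl on the urea-bearing ring

This account rests on a few compounds, and the source may have more. Where it says the series, first, only, none or still open, it means among the compounds named here.

Measured so far:
Compound 1, `CCc1ccccc1NC(=O)N[C@H](C)c1ccccc1`, gives 101% in an ADME assay on the whole organism with Oryza sativa as the target, tested at 0.1 uM; a lower number here means a stronger effect, a higher number a weaker effect of the compound at the concentration tested.
Compound 2, `CCc1ccccc1NC(=O)N[C@@H](C)c1ccccc1`, gives 100%.
Compound 3, `C[C@H](NC(=O)Nc1ccc(C(C)(C)C)cc1)c1ccccc1`, gives 100%.

Compound 2 stands level with compound 3 at the digits shown, and the two together are the lowest of the three numbers; compound 1 lies furthest from compound 2, yet the step of a number 1 percentage points lower from compound 1 to compound 2 (within the scatter) is within the scatter, and that step is a matter of drawn configuration only, because of the fact that compounds 1 and 2 differ only in the configuration as drawn. All three values sit together, so the series shows no separation so far.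

Compound 4, `C[C@H](NC(=O)Nc1ccccc1Br)c1ccccc1`, differs from compound 2 by bromo in place of ethyl on an aromatic carbon. Among the measured compounds shown here, no measured step changes a ring substituent, so nothing among the measured pairs speaks directly to this change; the one available step is the configuration step from compound 1 to compound 2, and it was within the scatter. With every measured value resting at the same level, compound 4 is expected to show no movement beyond the scatter, the step of a number 1 percentage points lower from compound 2 to compound 4 (within the scatter) being the estimate. Compound 4 is therefore estimated at 99%, with a range from 85% to 108%.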

Compound 4, a percentage reported as activity, at one concentration (the size of the read-out at that concentration, not a potency): 101%
For compound 4 the middle estimate is 2 percentage points below the measured one, and the stated range covers the measured number.
By their numbers in this assay, from the lowest: compounds 2, 3, 1 and 4 (each within the scatter of the next).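

In this assay, bromo in place of ethyl on an aromatic carbon, ortho to a large group, gives a number 1 percentage points higher from compound 2 to compound 4 (within the scatter). Among the compounds shown here, this is the first measured step at a ring substituent, and it shows that this position accepts a single bromine atom in place of the two-carbon ethyl group with no change beyond the scatter at the concentration tested. Nothing in the information available accounts for this result, as the only fact at hand concerns drawn configuration and not this exchange.

The compounds shown leave open whether any group at this position can move the read-out beyond the scatter, as a carboxylic acid, an amine or a longer chain might. For the compounds shown here, they also leave open whether the same exchange would behave alike on the other configuration, the one drawn in compound 1.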